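Compound 2 and one exchanged aryl group

The source may hold more compounds than are shown below. What is called first, only, known or untested is meant among the compounds shown, and "the series" means these compounds.

In a functional assay on HepG2 cells (Homo sapiens) for antiproliferative activity, read by sulforhodamine B assay, with a stated time of 48 h (a higher number here means a weaker inhibitor, a lower number a stronger inhibitor), compound 1 `COc1cc(C=C(C(=O)/C=C/c2cccc(OC)c2OC)C(=O)/C=C/c2cccc(OC)c2OC)cc(Br)c1O` gives 240 nM and compound 2 `COc1ccc(OC)c(/C=C/C(=O)C(=Cc2ccc(OC)c(OC)c2)C(=O)/C=C/c2cc(OC)ccc2OC)c1` gives 260 nM as its value, so the two lie within the scatter of each other. Compound 3 `COc1ccc(OC)c(/C=C/C(=O)C(=Cc2cc(OC)c(O)c(OC)c2)C(=O)/C=C/c2cc(OC)ccc2OC)c1` differs from compound 2 in one place, by 4-hydroxy-3,5-dimethoxyphenyl in place of 3,4-dimethoxyphenyl on a double-bonded chain carbon bound to a double-bonded chain carbon in all: 4-hydroxy-3,5-dimethoxyphenyl in place of 3,4-dimethoxyphenyl on a double-bonded chain carbon bound to a double-bonded chain carbon. Going by the values given here, no measured pair shows what this change does, so no shift beyond the scatter is expected in this assay for now. The expected step is a 1.2-fold lower number from compound 2 to compound 3 (0.07 log units; within the scatter) and no more. For compound 3 the estimated value is 220 nM with an expected range from 80 nM to 600 nM in this test.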

Compound 3, half-maximal inhibitory concentration: 210 nM
Compound 3: middle estimate off by 1.0-fold (0.02 log units), on the high side; the range from low to high includes it.
By their numbers in this assay, from the lowest: compounds 3, 1 and 2 (each within the scatter of the next).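

In this assay, exchanging 3,4-dimethoxyphenyl for 4-hydroxy-3,5-dimethoxyphenyl on a double-bonded chain carbon bound to a double-bonded chain carbon gives a 1.2-fold lower number from compound 2 to compound 3 (0.09 log units; within the scatter). This first step read at this position shows that the larger aryl group, with its hydrogen-bond donor, is accepted without a shift beyond the scatter. Nothing at hand offers a reason for this result.

Going by these compounds, whether an aryl group carrying an amine or a carboxylic acid at this place would move the number beyond the scatter remains open. The compounds shown also do not separate any contribution of the hydroxy group from that of the rearranged methoxy groups.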